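The compounds below may be only part of what the source reports. "The series", "measured", "known", "first", "only" and "open" are said of these compounds alone.

Of the compounds shown here, three sharing one core have been measured in an ADME assay on MDCKII-LE cells (Canis lupus familiaris) for permeability, read by transwell migration, in the apical to basolateral direction; on this read-out lower numbers stand for lower permeability and higher numbers for higher permeability. There, compound 1 `CC1(C)C[C@H](CN([C@H](CCC(F)(F)F)C(N)=O)S(=O)(=O)c2ccc(Cl)cc2)O1` gives 18.1 10^-6 cm/s, compound 2 `CC1(C)CO[C@H]1CN([C@H](CCC(F)(F)F)C(N)=O)S(=O)(=O)c1ccc(Cl)cc1` gives 26.4 10^-6 cm/s and compound 3 `NC(=O)[C@@H](CCC(F)(F)F)N(C[C@H]1CCCOC1)S(=O)(=O)c1ccc(Cl)cc1` gives 18.2 10^-6 cm/s. Compound 1 therefore stands within the scatter of both others, and the three numbers cannot be ranked. Still unmeasured is compound 4 `NC(=O)[C@@H](CCC(F)(F)F)N(C[C@@H]1CCCOC1)S(=O)(=O)c1ccc(Cl)cc1`, which is reached from compound 1 by this change: oxan-3-yl in place of 4,4-dimethyloxetan-2-yl on a saturated chain carbon bound to a sulfonamide nitrogen. In words, oxan-3-yl takes the place of 4,4-dimethyloxetan-2-yl on a saturated chain carbon bound to a sulfonamide nitrogen. The same words describe the closest measured step, a 1.0-fold higher number from compound 1 to compound 3 (0.00 log units; within the scatter), and compound 3 differs from compound 4 only in the defined stereocentre of the oxan-3-yl group. The two remaining steps, a 1.5-fold higher number from compound 1 to compound 2 (0.16 log units; within the scatter) and a 1.5-fold lower number from compound 2 to compound 3 (0.16 log units; within the scatter), also stay within the scatter. Within the data shown here, no measurement yet compares the two arrangements at that stereocentre, so the range has to stay fairly wide. No change beyond the scatter is expected in this assay, and the expected step is a 1.0-fold higher number from compound 1 to compound 4 (0.02 log units; within the scatter). For compound 4 the estimated value is 19 10^-6 cm/s, with an expected range from 11 10^-6 cm/s to 32 10^-6 cm/s.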

Compound 4, apparent permeability: 18.4 10^-6 cm/s
For compound 4 the middle estimate is 1.0-fold (0.01 log units) above the measured one; measured number inside the range.
By their numbers in this assay, from the lowest: compounds 1, 3, 4 and 2 (each within the scatter of the next).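

In this assay, the drawn configuration at the oxan-3-yl stereocentre does not separate the two compounds, with a 1.0-fold higher number from compound 3 to compound 4 (0.00 log units; within the scatter), and that step isolates this one feature: the fact that compounds 3 and 4 differ only in the configuration as drawn The other arrangement of oxan-3-yl now gives the same picture as the first against both dimethyloxetane groups, with a 1.0-fold higher number from compound 1 to compound 4 (0.01 log units; within the scatter) and a 1.4-fold lower number from compound 2 to compound 4 (0.16 log units; within the scatter). On a saturated chain carbon bound to a sulfonamide nitrogen, neither the exchange of the four-membered ring for the six-membered ring nor the inversion of the oxan-3-yl stereocentre moves any of the four compounds beyond the scatter of the others.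

All four groups compared here carry 6 heavy atoms, a single ring oxygen and no net charge, so the compounds shown leave open whether an amine, a carboxylic acid or an open chain at this place would stay as close. They also leave open whether the two arrangements of oxan-3-yl would remain this close on a core other than the shared one, since every comparison here rests on that core and on this one read-out.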